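Extending a fluorophenyl arm by a double bond

This account rests on a few compounds, and the source may have more. Where it says the series, first, only, none or still open, it means among the compounds named here.

Three compounds have so far been measured in a functional assay on MCF7 cells (Homo sapiens) for cytotoxicity, read by MTT assay, with a stated time of 2 days, tested at 0.1 uM; on this read-out higher numbers stand for a weaker effect at the one concentration tested and lower numbers for a stronger effect:
compound 1 `CC(=O)c1cc(-c2ccc(F)cc2)cc2cc(-c3ccccc3)[nH]c12`: 98.3%
compound 2 `CC(=O)c1cc(-c2ccc(F)cc2)cc2cc(-c3ccc(F)cc3)[nH]c12`: 99.8%
compound 3 `COc1ccc(-c2cc3cc(-c4ccc(F)cc4)cc(C(C)=O)c3[nH]2)cc1`: 97.3%

On these numbers compound 1 stands second highest of the three, though all three lie within the scatter of one another: the nearest is compound 3, at a number 1 percentage points lower from compound 1 to compound 3 (within the scatter), and the furthest is compound 2, at a number 1.5 percentage points higher from compound 1 to compound 2 (within the scatter). The remaining step, a number 2.5 percentage points lower from compound 2 to compound 3 (within the scatter), is likewise within the scatter. The next compound is compound 4 `CC(=O)c1cc(/C=C/c2ccc(F)cc2)cc2cc(-c3ccccc3)[nH]c12`, which has not yet been measured. It differs from compound 1 in one place: 2-(4-fluorophenyl)ethenyl in place of 4-fluorophenyl on an aromatic carbon. Among the compounds with values here, none of the measured steps concerns this place; each of them exchanges a group elsewhere in the shared core, and each stayed within the scatter. Within the data shown here, there is therefore no measured step that bears directly on the change, and the expectation rests only on how little any of the three numbers has moved. Compound 4 is expected to show a step of a number 1.3 percentage points lower from compound 1 to compound 4 (within the scatter), that is, none beyond the scatter. Compound 4 is accordingly estimated at 97%. The low end expected for compound 4 is 85% and the high end for compound 4 is 103%.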

Compound 4, a percentage reported as activity, at one concentration (the size of the read-out at that concentration, not a potency): 89.7%
Beside the measured number, compound 4's estimate is 7.3 percentage points above it; the measured number falls inside the stated range.
By their numbers in this assay, from the lowest: compounds 4, 3, 1 and 2 (each within the scatter of the next, the first and the last beyond it).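

Within the data shown here, compound 4 is the first of the series to carry a change on the aromatic carbon meta to the acetyl group, and in this assay the exchange of 4-fluorophenyl for 2-(4-fluorophenyl)ethenyl there gives a number 8.6 percentage points lower from compound 1 to compound 4 (within the scatter). Among these compounds, this is larger than any step among the earlier compounds, which all concerned the other aryl group, yet it still lies within the scatter, so at this single concentration the longer arm, with its one double bond outside the aromatic rings, cannot be said to alter the read-out. Nothing measured here offers an explanation for the size of this step.

Open, as far as these compounds go, is whether a saturated ethyl link in place of the double bond, or an amine or a carboxylic acid in place of the fluoro on this arm, would carry the read-out beyond the scatter. Also open, from the compounds shown here alone, is how compound 4 would behave at higher concentrations, since one concentration gives the size of a read-out and not a potency.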